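The source may report more compounds than this note shows. Statements on the series, on what has been measured and on what is new or still open speak of the compounds shown alone.

Three compounds have so far been measured in a functional assay on SK-BR-3 cells (Homo sapiens) for antiproliferative activity; on this read-out lower numbers stand for stronger inhibition and higher numbers for weaker inhibition:

Compound 1 `COc1cccc(Oc2ccc3cc(NC(=O)c4ccc(O)c(CC=C(C)C)c4)c(=O)oc3c2C)c1`: 33100 nM
Compound 2 `CC(C)=CCc1cc(C(=O)Nc2cc3ccc(Oc4ccc(C(C)(C)C)cc4)c(C)c3oc2=O)ccc1O`: 68300 nM
Compound 3 `COc1cccc(Cc2ccc3cc(NC(=O)c4ccc(O)c(CC=C(C)C)c4)c(=O)oc3c2C)c1`: 14800 nM

Compound 3 gives the lowest number of the three, reached through a 2.2-fold lower number from compound 1 to compound 3 (0.35 log units; beyond the scatter) and a 4.6-fold lower number from compound 2 to compound 3 (0.66 log units; beyond the scatter). Compound 4 `COc1ccc(Cc2ccc3cc(NC(=O)c4ccc(O)c(CC=C(C)C)c4)c(=O)oc3c2C)cc1OC` differs from compound 3 by methoxy in place of hydrogen on an aromatic carbon, the new group sitting ortho to a methoxy group and para to a large group. For the measured compounds named here, none of the measured steps bears on this change: all three alter the group on the other side of the shared core, and none adds a methoxy to an existing ring. There is thus no basis for expecting a step beyond the scatter in this assay. Compound 4 is therefore estimated at 15000 nM, between 5000 nM and 45000 nM, an expected step of a 1.0-fold higher number from compound 3 to compound 4 (0.01 log units; within the scatter).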

Compound 4, half-maximal inhibitory concentration: > 100000 nM
Compound 4: no number, only a limit (the forecaster's own chance of this, stated with the estimate: 15%); middle value at least 6.6-fold (0.82 log units) from the limit.
By their numbers in this assay, from the lowest: compound 3; then compound 1; then compound 2. At a limit, above all of these: compound 4.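

In this assay, methoxy in place of hydrogen on this aromatic carbon, ortho to a methoxy group and para to a large group, is no neutral change: it gives an at least 6.7-fold higher number from compound 3 to compound 4 (0.82 log units; beyond the scatter). The 3,4-dimethoxybenzyl group also gives an at least 3.0-fold higher number from compound 1 to compound 4 (0.48 log units; beyond the scatter) and an at least 1.4-fold higher number from compound 2 to compound 4 (0.16 log units; that floor lies within the scatter), though the floor of the latter step lies within the scatter. Compound 4 carries a limit of the assay, not a number: the limit of > 100000 nM in this assay, at which 1 of the 4 values shown sits.

As far as these compounds go, whether hydroxy or fluorine on this same carbon would give a step of similar size remains open. So does how far compound 4 lies past its limit.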